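The source may hold more compounds than are shown below. What is called first, only, known or untested is meant among the compounds shown, and "the series" means these compounds.

The three measured compounds share one core and differ only in what sits on the amide-type nitrogen or beyond it. Compound 1 `Cc1cc(C)cc(S(=O)(=O)c2c(C(=O)NC3CNC3)[nH]c3ccc(Cl)cc23)c1` carries an azetidin-3-yl there; in an ADME assay on MT4 cells (Homo sapiens) for cytotoxicity, read by MTT assay, with a stated time of 5 days (on this read-out lower numbers stand for higher toxicity in this test and higher numbers for lower toxicity in this test), compound 1 gives 37300 nM. Compound 2 `Cc1cc(C)cc(S(=O)(=O)c2c(C(=O)NC3CN(Cc4cccnc4)C3)[nH]c3ccc(Cl)cc23)c1`, with (pyridin-3-yl)methyl in place of hydrogen on the amine nitrogen in the ring, gives 36000 nM, and compound 3 `Cc1cc(C)cc(S(=O)(=O)c2c(C(=O)NS(C)(=O)=O)[nH]c3ccc(Cl)cc23)c1`, with methylsulfonyl on the amide-type nitrogen, gives 40200 nM. Compound 1 thus stands second highest of the three numbers, and a 1.0-fold lower number from compound 1 to compound 2 (0.02 log units; within the scatter) and a 1.1-fold higher number from compound 1 to compound 3 (0.03 log units; within the scatter) are both within the scatter, as is a 1.1-fold higher number from compound 2 to compound 3 (0.05 log units; within the scatter).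

Compound 4 `CCS(=O)(=O)NC(=O)c1[nH]c2ccc(Cl)cc2c1S(=O)(=O)c1cc(C)cc(C)c1` has not yet been measured. It differs from compound 1 in one place: ethylsulfonyl in place of azetidin-3-yl on an amide-type nitrogen. The step that bears on it most directly is a 1.1-fold higher number from compound 1 to compound 3 (0.03 log units; within the scatter), where methylsulfonyl entered at the same place and the number stayed within the scatter; a 1.1-fold higher number from compound 2 to compound 3 (0.05 log units; within the scatter) points the same way. Compound 4 is therefore expected to show no step beyond the scatter in this assay, and its estimated step is a 1.0-fold higher number from compound 1 to compound 4 (0.01 log units; within the scatter). Compound 4 is estimated at 38000 nM, with a range from 25000 nM to 58000 nM.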

Compound 4, half-maximal cytotoxic concentration: > 283000 nM
Compound 4 gave a limit, no number (the forecaster's own chance of this, stated with the estimate: 10%); middle value at least 7.4-fold (0.87 log units) from the limit.
By their numbers in this assay, from the lowest: compounds 2, 1 and 3 (each within the scatter of the next). At a limit, above all of these: compound 4.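

Compound 4 stands at a limit of this assay, not at a number: the limit of > 283000 nM in this assay, at which 1 of the 4 values shown sits. For the compounds shown here, the sharpest comparison is an at least 7.0-fold higher number from compound 3 to compound 4 (0.84 log units; beyond the scatter), where the only change is methyl in place of hydrogen on a saturated chain carbon bound to a sulfonyl sulfur, so at this place on the amide-type nitrogen, methylsulfonyl and ethylsulfonyl are not interchangeable in this read-out. The other two steps, an at least 7.5-fold higher number from compound 1 to compound 4 (0.88 log units; beyond the scatter) and an at least 7.8-fold higher number from compound 2 to compound 4 (0.89 log units; beyond the scatter), are also beyond the scatter, which sets ethylsulfonyl apart from azetidin-3-yl and from 1-((pyridin-3-yl)methyl)azetidin-3-yl, whereas the earlier changes on this nitrogen or beyond it had all stayed within the scatter.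

The compounds shown leave open how far the true figure for compound 4 lies past its limit, so each of these steps gives only a lower bound on its size. They also leave open whether a longer chain on the sulfonyl sulfur, such as propyl or butyl, or a phenyl ring there, would stay at this limit or return to the level of compound 3, as this single pair of sulfonyl groups shows no trend.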